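The source may hold more compounds than are shown below. What is called first, only, known or untested is meant among the compounds shown, and "the series" means these compounds.

Measured in a functional assay on MCF7 cells (Homo sapiens) for cytotoxicity, read by MTT assay, with a stated time of 48 h; a higher number here means a weaker inhibitor, a lower number a stronger inhibitor:
- compound 1 `Cc1n[nH]c2c1C(c1ccc(N(C)C)cc1)C(C(=O)NN)=C(N)N2`: 42600 nM
- compound 2 `Cc1n[nH]c2c1C(c1ccc(N(C)C)cc1)C(C(=O)NNC(N)=S)=C(N)N2`: 5210 nM
- compound 3 `Cc1n[nH]c2c1C(c1ccc(N(C)C)cc1)C(C(=O)N/N=C1/C(=O)Nc3ccccc31)=C(N)N2`: 59100 nM

Compound 1 belongs to the upper pair of these three numbers. The step of a 1.4-fold higher number from compound 1 to compound 3 (0.14 log units; within the scatter) stays inside the scatter, whereas the step of an 8.2-fold lower number from compound 1 to compound 2 (0.91 log units; beyond the scatter) goes beyond it.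

Compound 4 `Cc1n[nH]c2c1C(c1ccc(N(C)C)cc1)C(C(N)=O)=C(N)N2` has not yet been measured. Its difference from compound 1 is hydrogen in place of amino on an amide-type nitrogen, which turns aminocarbamoyl into carbamoyl.

For the measured compounds named here, no measured step makes this exact change, but two alter the same aminocarbamoyl group of compound 1. Only one of them moved the number beyond the scatter, and the step of an 11-fold higher number from compound 2 to compound 3 (1.05 log units; beyond the scatter) shows how far apart two changes at this place can land. The three compounds therefore show that this place can matter, but they give no direction for removing the amino group. The step of a 1.4-fold higher number from compound 1 to compound 3 (0.14 log units; within the scatter), despite its large added group, suggests that change here need not shift this assay, so no step beyond the scatter is expected.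

The step expected is a 1.1-fold lower number from compound 1 to compound 4 (0.03 log units; within the scatter). For compound 4 the estimated value is 40000 nM, with an expected range from 15000 nM to 100000 nM.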

Compound 4, half-maximal inhibitory concentration: 4550 nM
The estimate for compound 4 lay 8.8-fold (0.94 log units) above the measured number; measured number outside the range, below it.
By their numbers in this assay, from the lowest: compounds 4 and 2 (each within the scatter of the next); then compounds 1 and 3 (each within the scatter of the next).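

In this assay, the change from aminocarbamoyl to carbamoyl proves to matter at this place: a 9.4-fold lower number from compound 1 to compound 4 (0.97 log units; beyond the scatter), so this amide-type nitrogen gives the lower number without any group in place of the hydrogen. The number of compound 2 therefore no longer stands alone, since a 1.1-fold lower number from compound 2 to compound 4 (0.06 log units; within the scatter), and the sulfur-bearing group of compound 2 cannot be told apart here from a plain hydrogen. By contrast, a 13-fold lower number from compound 3 to compound 4 (1.11 log units; beyond the scatter), which places compounds 1 and 3, with the smallest and the largest groups on this nitrogen, together at the higher numbers, so the number does not follow the size of the group across these four compounds.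

Going by these compounds, whether a methyl or an acetyl group on this nitrogen would fall with hydrogen or with amino stays open, as does whether a carboxylic acid in place of carbamoyl would hold the lower number. Nothing measured here accounts for why amino and the larger ring-bearing group stand apart from hydrogen and the sulfur-bearing group.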